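Compound 3 to compound 4: a step at the limit

The compounds below may be only part of what the source reports. "The series", "measured", "known", "first", "only" and "open" are said of these compounds alone.

In an ADME assay on HEK293 cells (Homo sapiens) for cytotoxicity, with a stated time of 6 h (on this read-out higher numbers stand for lower toxicity in this test and lower numbers for higher toxicity in this test), compound 1 (`CCCCNc1nc(N)nc2cccc(OC)c12`) gives > 25000 nM, which is a limit. Compound 2 (`CCCCNc1nc(N)nc2cccc(CC3CCCC3)c12`) reads > 25000 nM, also a limit. Compound 3 (`CCCCNc1nc(N)nc2cccc(C(=O)NC(C)C)c12`) reads > 25000 nM, again a limit. Going by the values given here, the series so far shows (the limit of > 25000 nM in this assay, at which 3 of the 3 values shown sit).

Compound 4 (`CCCCNc1nc(N)nc2cccc(C(=O)N[C@@H](C)c3ccccc3)c12`) has 1-phenylethyl in place of isopropyl on an amide-type nitrogen. The nearest measured steps are a step that the two limits leave unreadable from compound 1 to compound 3 and a step that the two limits leave unreadable from compound 2 to compound 3, and neither gives a size. Among the compounds with values here, no step of known size or direction therefore supports a shift, and none beyond the scatter is expected. The expected change is a step that the limit leaves unreadable from compound 3 to compound 4. For compound 4 the estimate in this assay is 30000 nM, with an expected range of 12000 nM to 60000 nM.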

Compound 4, half-maximal cytotoxic concentration: > 25000 nM
Compound 4: a limit, no number; the forecaster's own chance of this, stated with the estimate: 70%; the middle value lies beyond the limit too.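

The step from compound 3 to compound 4 cannot be read, as both values in this assay are limits. The compounds shown leave open which change on the shared core, if any, would give a measurable value, with the series standing at: the limit of > 25000 nM in this assay, at which 4 of the 4 values shown sit.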